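Urea Tail Variation on the Shared Core

The compounds below may be only part of what the source reports. "The series", "measured", "known", "first", "only" and "open" are said of these compounds alone.

Compound 3 `COc1cc(NC(C)CCCNC(=O)NC2CCCCC2)c2ncccc2c1` gives 94000 nM in an ADME assay on HEL cells (Homo sapiens) for cytotoxicity (on this read-out higher numbers stand for lower toxicity in this test and lower numbers for higher toxicity in this test), the highest of the two numbers in hand. Its nearest neighbour is compound 2 `COc1cc(NC(C)CCCNC(=O)NC2CCCC2)c2ncccc2c1` with 56000 nM; the step of a 1.7-fold higher number from compound 2 to compound 3 (0.22 log units; within the scatter) is within the scatter. Compound 1 `CCN(CC)C(=O)NCCCC(C)Nc1cc(OC)cc2cccnc12` returns only a limit, > 100000 nM in this assay. That limit, (the limit of > 100000 nM in this assay, at which 1 of the 3 values shown sits), makes the steps of an at least 1.7-fold lower number from compound 1 to compound 2 (0.25 log units; that floor lies within the scatter) and an at least 1.0-fold lower number from compound 1 to compound 3 (0.02 log units; that floor lies within the scatter) floors only, both inside the scatter. Among the compounds with values here, no step in this assay has yet moved beyond the scatter.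

Compound 4 `COc1cc(NC(C)CCCNC(=O)n2nnc3ccccc32)c2ncccc2c1` carries the change (a group of 9 heavy atoms (6 carbon, 3 nitrogen; one five-membered aromatic ring with 3 hetero atoms, one six-membered aromatic ring of carbon only) in place of a group of 7 heavy atoms (6 carbon, 1 nitrogen; one six-membered non-aromatic ring of carbon only), on a carbonyl carbon). Nothing measured bears on an aromatic group at this position, so no step beyond the scatter is expected: a 1.2-fold lower number from compound 3 to compound 4 (0.07 log units; within the scatter). Compound 4 is estimated at 80000 nM, in the range 30000 nM to 200000 nM.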

Compound 4, half-maximal cytotoxic concentration: 72000 nM
Estimate against measurement, compound 4: 1.1-fold (0.05 log units) above; low and high end bracket the measured number.
By their numbers in this assay, from the lowest: compounds 2, 4 and 3 (each within the scatter of the next). At a limit, above all of these: compound 1.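

On this assay, the aromatic group on a carbonyl carbon, with one five-membered aromatic ring with 3 hetero atoms and one six-membered aromatic ring of carbon only, gives a 1.3-fold lower number from compound 3 to compound 4 (0.12 log units; within the scatter) and a 1.3-fold higher number from compound 2 to compound 4 (0.11 log units; within the scatter). An aromatic group at this position, with 0 hydrogen-bond donors against 1 on cyclohexylamino, therefore stays within the scatter of both non-aromatic ring groups. The diethylamino tail stands at a limit, which leaves an at least 1.3-fold lower number from compound 1 to compound 4 (0.14 log units; that floor lies within the scatter) as a floor only: the limit of > 100000 nM in this assay, at which 1 of the 4 values shown sits.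

Still open, on these data alone, is whether a carboxylic acid or a primary amine on the carbonyl carbon would move the number beyond the scatter. As far as these compounds go, a longer chain in the tail remains equally open.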